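The compounds below may be only part of what the source reports. "The series", "measured", "known", "first", "only" and "open" are said of these compounds alone.

compound 1 `O=C1C(Nc2ccccc2)=CC(=O)c2c1nc1n2[C@H]2OC[C@@H](O)[C@H]2OC1`: > 8000 nM (a limit)
compound 2 `CCc1ccc(NC2=CC(=O)c3nc4n(c3C2=O)[C@H]2OC[C@@H](O)[C@H]2OC4)cc1`: 3990 nM
compound 3 `O=C1C=C(Nc2cccc(F)c2)C(=O)c2c1nc1n2[C@H]2OC[C@@H](O)[C@H]2OC1`: 6440 nM

In a functional assay on HeLa cells (Homo sapiens) for inhibition, read by sulforhodamine B assay (a lower number here means a stronger inhibitor, a higher number a weaker inhibitor), compound 1 gives > 8000 nM, which is a limit and not a number. This places compound 1 at the limit of > 8000 nM in this assay, at which 1 of the 3 values shown sits.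

The next compound is compound 4 `O=C1C(N2CCCCC2)=CC(=O)c2c1nc1n2[C@H]2OC[C@@H](O)[C@H]2OC1`, with piperidin-1-yl in place of anilino on a double-bonded ring carbon.

Among the measured compounds shown here, no measured step starts from compound 1, and none replaces an aromatic ring on the amine nitrogen with a non-aromatic one. For the measured compounds named here, the only measured step is a 1.6-fold higher number from compound 2 to compound 3 (0.21 log units; within the scatter). It exchanges one substituted phenyl for another, so it bears on the present change only indirectly. Its small size gives no ground for expecting a direction in this assay, and no step beyond the scatter is expected.

The expected step is a number no higher from compound 1 to compound 4 (the limit leaves the size open), and it remains loose since compound 1 has only a limit. A second result reported only as a limit is quite possible.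

For compound 4 the estimated value is 8000 nM, with an expected range of 3000 nM to 20000 nM.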

Compound 4, half-maximal inhibitory concentration: > 16000 nM
Compound 4: a limit, no number (the forecaster's own chance of this, stated with the estimate: 50%); middle value at least 2.0-fold (0.30 log units) from the limit.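

In this assay compound 4 gives > 16000 nM, which is a limit and not a number. Compound 1 also stands only as a limit, and the step between compound 1 and compound 4 cannot be read. The compounds shown leave open how far piperidin-1-yl and anilino differ on the shared core.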